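A Urea Swap at the Edge of Measurable Growth Inhibition

This account rests on a few compounds, and the source may have more. Where it says the series, first, only, none or still open, it means among the compounds named here.

Within the data shown here, compound 1 `O=C(Nc1ccc(Br)cc1)Nc1ccc(Nc2ncnc3c2OCCN3)cc1` is the only compound with a plain number in a functional assay on BaF3 cells (Mus musculus) for inhibition, read by MTT assay, with a stated time of 3 days (on this read-out lower numbers stand for stronger inhibition of growth and higher numbers for weaker inhibition of growth), where compound 1 gives 10000 nM. Compound 2 `O=C(Nc1ccc(Nc2ncnc3c2OCCN3)cc1)Nc1cccc2ccccc12` reaches only a limit of the assay, giving > 10000 nM in this assay. The step of a number no lower from compound 1 to compound 2 (the limit leaves the size open) is open in size because of the limit of > 10000 nM in this assay, at which 1 of the 2 values shown sits. Compound 3 `CC(C)(C)c1cc(NC(=O)Nc2ccc(Nc3ncnc4c3OCCN4)cc2)no1` carries the change (5-(tert-butyl)-1,2-oxazol-3-yl in place of 4-bromophenyl on an amide-type nitrogen). Among the measured compounds shown here, no measured step covers this replacement, and the single known step shows no gain. Compound 3 is therefore estimated at 8000 nM, with a range from 2000 nM to 20000 nM. The expected step of a 1.3-fold lower number from compound 1 to compound 3 (0.10 log units; within the scatter) stays within the scatter.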

Compound 3, concentration for 50% growth inhibition: > 10000 nM
Compound 3: no number, only a limit (the forecaster's own chance of this, stated with the estimate: 50%); middle value at least 1.2-fold (0.09 log units) away from the limit.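

With this assay, the 5-(tert-butyl)-1,2-oxazol-3-yl group gives a number no lower from compound 1 to compound 3 (the limit leaves the size open). A five-membered aromatic ring with hetero atoms thus joins naphthalen-1-yl as a second replacement for 4-bromophenyl on this amide-type nitrogen that shows no gain. The step between compound 2 and compound 3 cannot be read, and these compounds cannot be ranked because limits dominate the data: the limit of > 10000 nM in this assay, at which 2 of the 3 values shown sit.

Still open, from the compounds shown here alone, is whether any group at this nitrogen can bring the number clearly below that of compound 1. A 3-(trifluoromethyl)phenyl or 4-chlorophenyl group would test this.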